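From Hydroxy to Propoxy: One Small Change

The source may hold more compounds than are shown below. What is called first, only, known or untested is meant among the compounds shown, and "the series" means these compounds.

In a functional assay on MT4 cells (Homo sapiens) for cytotoxicity (on this read-out higher numbers stand for weaker inhibition and lower numbers for stronger inhibition), compound 3 (`Cc1cc(O)cc(S(=O)(=O)c2cccc(N)c2C#N)c1`) gives 167000 nM, while compound 1 (`N#Cc1c(N)cccc1Sc1cc(Cl)cc(Cl)c1`) gives 3000 nM. Compound 3 has the higher of these two numbers, and the gap between them lies beyond the usual scatter. Compound 2 (`Cc1cccc([S+]([O-])c2cccc(N)c2C#N)c1`) reads > 200000 nM, which is a limit of this assay and not a number.

Compound 4 (`CCCOc1cc(C)cc(S(=O)(=O)c2cccc(N)c2C#N)c1`) differs from compound 3 in one place: propyl in place of hydrogen on an oxygen on an aromatic ring. In words, propyl takes the place of hydrogen on an oxygen on an aromatic ring, turning hydroxy into propoxy.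

Among the compounds with values here, no measured pair shows this change on its own, so any expectation is loose. Compound 1 at 3000 nM shows that a much lower number is possible among these compounds. Compound 2 stands at its limit and offers no number to compare. A moderate move toward stronger inhibition, beyond the scatter, seems likely but is not assured. The expected change is a 3.3-fold lower number from compound 3 to compound 4 (0.52 log units; beyond the scatter). Compound 4 is estimated at 50000 nM, with an expected range of 12000 nM to 200000 nM.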

Compound 4, half-maximal inhibitory concentration: 11000 nM
Compound 4: middle estimate off by 4.5-fold (0.66 log units), on the high side; measured number below the stated range.
By their numbers in this assay, from the lowest: compound 1; then compound 4; then compound 3. At a limit, above all of these: compound 2.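

Going from hydroxy to propoxy gives a 15-fold lower number from compound 3 to compound 4 (1.18 log units; beyond the scatter) in this assay, and this is the first step in the set that isolates a single change. It shows that this oxygen on an aromatic ring is a place where one change alone can move the number well beyond the scatter, toward stronger inhibition in this read-out. Compound 2 is the only compound at a limit, which is not a number, so it offers no comparison for this change: the limit of > 200000 nM in this assay, at which 1 of the 4 values shown sits.

A single step cannot separate the effect of removing the hydrogen on this oxygen from the effect of the propyl chain itself; methoxy, a longer chain such as butoxy, or a chain ending in an amine at the same place would help to do so. On these data alone, the step gives the size of the change but not its cause, and whether the same change would act similarly on other compounds in the set remains open.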